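A Limit Shared, and One Side Chain Changed

The source may report more compounds than this note shows. Statements on the series, on what has been measured and on what is new or still open speak of the compounds shown alone.

Compound 1 `C/C=C(\C)C(=O)O[C@H]1[C@]2(C)C[C@@H]3O[C@@]1(O)C=C1C4=CC(=O)O[C@@H](c5ccoc5)[C@]4(C)CC[C@@H]1[C@]3(C)[C@@H]2C(=O)C(=O)OC`: > 100000 nM
Compound 2 `C/C=C(\C)C(=O)O[C@@H]1[C@]2(OC(=O)CCCC)C=C3C4=CC(=O)O[C@@H](c5ccoc5)[C@]4(C)CC[C@@H]3[C@@]3(C)[C@H](C[C@]1(C)[C@H]3[C@@H](OC(=O)CCCC)C(=O)OC)O2`: > 100000 nM
Compound 3 `C/C=C(\C)C(=O)O[C@@H]1[C@]2(OC(=O)C3CC3)C=C3C4=CC(=O)O[C@@H](c5ccoc5)[C@]4(C)CC[C@@H]3[C@@]3(C)[C@H](C[C@]1(C)[C@H]3[C@@H](OC(=O)C1CC1)C(=O)OC)O2`: > 100000 nM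

All three compounds were tested in a functional assay on HeLa cells (Homo sapiens) for inhibition, read by MTT assay, with a stated time of 24 h; a lower number here means a stronger inhibitor, a higher number a weaker inhibitor. None of them gave a number. Compound 1 stands at > 100000 nM, and this value is a limit of the assay, not a measured number. The same holds for the other two: the limit of > 100000 nM in this assay, at which 3 of the 3 values shown sit. For the measured compounds named here, no two measured compounds differ in one place alone, so the series offers no measured step to guide a prediction.

Compound 4 `C/C=C(\C)C(=O)O[C@H]1[C@]2(C)C[C@@H]3O[C@@]1(O)C=C1C4=CC(=O)O[C@@H](c5ccoc5)[C@]4(C)CC[C@@H]1[C@]3(C)[C@@H]2[C@@H](OC(C)=O)C(=O)OC` keeps the core of compound 1 and changes a single group, with acetoxy(methoxycarbonyl)methyl in place of (methoxycarbonyl)carbonyl on a saturated ring carbon. Going by the values given here, nothing measured so far shows that this change would bring activity in this assay. The step is therefore expected to be small, with little or no move toward stronger inhibition. The expectation rests on compound 1, whose limit of > 100000 nM gives only a starting floor. The expected change is an at least 1.1-fold lower number from compound 1 to compound 4 (0.04 log units; that floor lies within the scatter). For compound 4 the estimated value is 90000 nM, with an expected range from 30000 nM to 200000 nM, and a reading at the limit of the assay is quite possible.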

Compound 4, half-maximal inhibitory concentration: > 100000 nM
Compound 4 gave a limit, no number; the forecaster's own chance of this, stated with the estimate: 70%; middle value at least 1.1-fold (0.04 log units) away from the limit.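

For the compounds shown here, compound 1 and compound 4 both stand at a limit in this assay, so no step between them can be read: the limit of > 100000 nM in this assay, at which 4 of the 4 values shown sit. The compounds shown leave open how far acetoxy(methoxycarbonyl)methyl in place of (methoxycarbonyl)carbonyl changes inhibition, and whether any change to the shared core gives a measurable value.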